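Swapping a urea ring for a carbon-only spirocycle

A few compounds are considered here, and "the series" means these few. Any claim that something is new, unique, unknown or untested is made for them only; others in the source may bear on it.

Compounds measured in an assay on HEK293 cells for negative allosteric modulation of metabotropic glutamate receptor 5 (Homo sapiens), read by FLIPR; a higher number here means a weaker inhibitor, a lower number a stronger inhibitor:
Compound 1 `O=C(N1CCCCC1)N1CC(c2nc(-c3cccc(Cl)c3)no2)C1` gives > 10000 nM, a limit of the assay.
Compound 2 `O=C(C1CCCO1)N1CC(c2nc(-c3cccc(Cl)c3)no2)C1` gives 890 nM.
Compound 3 `CC1CCN(C(=O)N2CC(c3nc(-c4cccc(Cl)c4)no3)C2)CC1` gives > 10000 nM, a limit of the assay.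

Compound 3 thus stands at the assay limit, and so does compound 1 (the limit of > 10000 nM in this assay, at which 2 of the 3 values shown sit); only compound 2 has a real number. Compound 4 `O=C(C1CCC2(CCC2)CC1)N1CC(c2nc(-c3cccc(Cl)c3)no2)C1` differs from compound 3 by a group of 9 heavy atoms (9 carbon; one four-membered non-aromatic ring of carbon only, one six-membered non-aromatic ring of carbon only) in place of a group of 7 heavy atoms (6 carbon, 1 nitrogen; one six-membered non-aromatic ring with 1 hetero atom), on a carbonyl carbon. The measured steps that bear on this change are an at least 11-fold lower number from compound 1 to compound 2 (1.05 log units; beyond the scatter) and an at least 11-fold higher number from compound 2 to compound 3 (1.05 log units; beyond the scatter); in both, the compound carrying piperidin-1-yl or 4-methylpiperidin-1-yl on the carbonyl is the weaker one. Since compound 4 replaces that kind of ring with rings of carbon only, a large step toward a lower number is expected, an at least 6.6-fold lower number from compound 3 to compound 4 (0.82 log units; beyond the scatter). Compound 4 is therefore estimated at 1500 nM, with a range from 300 nM to 10000 nM.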

Compound 4, half-maximal inhibitory concentration: > 10000 nM
Compound 4: a limit, no number (the forecaster's own chance of this, stated with the estimate: 25%); middle value at least 6.6-fold (0.82 log units) away from the limit.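

Set against oxolan-2-yl on the carbonyl carbon, the carbon-only spirocycle gives an at least 11-fold higher number from compound 2 to compound 4 (1.05 log units; beyond the scatter). Compound 4 gives > 10000 nM, a limit of the assay. So removing the ring nitrogen of the piperidines does not restore a measurable value, the steps from compound 1 and compound 3 to compound 4 cannot be read, and only oxolan-2-yl gives a real number: the limit of > 10000 nM in this assay, at which 3 of the 4 values shown sit.

Going by these compounds, whether the oxygen of oxolan-2-yl or its smaller ring is what counts stays open. A cyclopentyl group on the same carbonyl would separate the two.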